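The compounds below may be only part of what the source reports. "The series", "measured", "known", "first", "only" and "open" are said of these compounds alone.

In a functional assay, with a stated time of 30 min, in the absence of a further agent (a lower number here means a stronger inhibitor, a higher number a weaker inhibitor), two compounds that share one core have been measured so far. Compound 1 `Cc1ccc(C(=O)Nc2nnc(-c3ccc(O)c(O)c3)s2)cc1` gives 34000 nM and compound 2 `O=C(COc1ccccc1)Nc1nnc(-c2ccc(O)c(O)c2)s1` gives 36100 nM, so these two values lie within the usual scatter of each other. Compound 3 `O=C(Nc1nnc(-c2ccc(O)c(O)c2)s1)C1CCCCC1` has not yet been measured. It keeps the shared core but carries a different group on the carbonyl carbon: cyclohexyl in place of phenoxymethyl on a carbonyl carbon. In words, cyclohexyl stands in place of phenoxymethyl. For the measured compounds named here, only one measured step involves a change at this place: a 1.1-fold higher number from compound 1 to compound 2 (0.03 log units; within the scatter). That exchange of phenoxymethyl for 4-methylphenyl stayed within the scatter, so no change beyond the scatter is expected here, although one step is thin evidence. As far as these compounds go, the expected step is a 1.0-fold lower number from compound 2 to compound 3 (0.01 log units; within the scatter), and its direction remains open. Compound 3 is estimated at 35000 nM, with an expected range of 14000 nM to 85000 nM.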

Compound 3, half-maximal inhibitory concentration: 37300 nM
Compound 3: middle estimate off by 1.1-fold (0.03 log units), on the low side; measured number inside the range.
By their numbers in this assay, from the lowest: compounds 1, 2 and 3 (each within the scatter of the next).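

In this assay the exchange of phenoxymethyl for cyclohexyl on a carbonyl carbon (a 1.0-fold higher number from compound 2 to compound 3 (0.01 log units; within the scatter)) and the exchange of 4-methylphenyl for cyclohexyl (a 1.1-fold higher number from compound 1 to compound 3 (0.04 log units; within the scatter)) both stay within the scatter. The two earlier groups each held an aromatic ring, whereas cyclohexyl brings a non-aromatic ring of carbon only and lacks the hydrogen-bond acceptor of phenoxymethyl, so neither an aromatic ring nor that acceptor is needed at this place to keep a number of this size. No measurement at hand explains why these three groups read alike.

As far as these compounds go, all three groups contain a ring of carbon, so it remains open whether an amine, a carboxylic acid or a longer chain on the carbonyl carbon would move the number beyond the scatter. From the compounds shown here alone, it also remains open whether a change in the shared core, held fixed in all three compounds, would do so.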